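The compounds below may be only part of what the source reports. "The series", "measured", "known", "first", "only" and "open" are said of these compounds alone.

Among the compounds with values here, in a functional assay on HCT-116 cells (Homo sapiens) for inhibition, read by sulforhodamine B assay, with a stated time of 3 days (a lower number here means a stronger inhibitor of growth, a higher number a weaker inhibitor of growth), compound 1 `O=C(/C=C/c1ccccc1Cl)c1ccc(OCc2ccccc2)cc1` gives 14900 nM, and this is the only true number available so far. Compound 2 `COc1ccc(CCC(=O)c2ccccc2)cc1` is reported as > 100000 nM, which is a limit of the assay and not a number. Within the data shown here, compound 1 therefore stands alone on the scale, with no measured step leading to or from it.

The next compound to be tested is compound 3 `O=C(/C=C/c1ccc(Cl)cc1)c1ccc(OCc2ccccc2)cc1`, which has the same atoms as compound 1, joined differently. The change is 4-chlorophenyl in place of 2-chlorophenyl on a double-bonded chain carbon bound to a double-bonded chain carbon. Among the measured compounds shown here, no measured pair shows what such a swap does in this assay, so neither direction can be favoured, and the best guide is compound 1 itself at 14900 nM. The step of a 1.1-fold lower number from compound 1 to compound 3 (0.03 log units; within the scatter) is expected to stay within the usual scatter of repeated measurements. With so little to go on, the expected range is wide. For compound 3 the estimated value is 14000 nM, with an expected range from 6000 nM to 35000 nM.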

Compound 3, concentration for 50% growth inhibition: > 50000 nM
Compound 3 ended at the assay's limit; the forecaster's own chance of this, stated with the estimate: 8%; at least 3.5-fold (0.55 log units) between middle value and limit.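

The swap of 2-chlorophenyl for 4-chlorophenyl on a double-bonded chain carbon bound to a double-bonded chain carbon gives, in this assay, an at least 3.3-fold higher number from compound 1 to compound 3 (0.52 log units; beyond the scatter). Within the data shown here, this is the first measured sign that the place of the chlorine on this ring matters: the two compounds have the same atoms, joined differently, yet a higher number here means a weaker inhibitor of growth, so compound 1 is the stronger of this pair by more than the usual scatter. The step has only a lower bound, as the value for compound 3 is a limit of the assay and not a number: the limit of > 50000 nM in this assay, at which 1 of the 3 values shown sits.

How far compound 3 really lies from compound 1 therefore stays unknown, and these values alone do not tell why moving the chlorine has this effect. Also open, on these data alone, is how the same place would read with a 3-chlorophenyl group, with a plain phenyl carrying no chlorine, or with a phenyl carrying an amine, any of which could show whether the chlorine itself is needed.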